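The source may hold more compounds than are shown below. What is called first, only, known or untested is meant among the compounds shown, and "the series" means these compounds.

Compound 1 `COc1cc(/C=C2\CCC/C(=C\c3ccccc3F)C2=O)cc(OC)c1OC` and compound 2 `COc1cc(/C=C2\CCC/C(=C\c3ccc(F)c(F)c3)C2=O)cc(OC)c1OC` share one core and differ only in the fluorinated phenyl group on the double-bonded chain carbon. In a functional assay on LoVo cells (Homo sapiens) for antiproliferative activity, read by MTT assay, with a stated time of 72 h (on this read-out lower numbers stand for stronger inhibition and higher numbers for weaker inhibition), compound 1 gives 1900 nM, while compound 2 gives 2300 nM. Within the data shown here, the step of a 1.2-fold higher number from compound 1 to compound 2 (0.08 log units; within the scatter) is the only measured step in this set. Among the measured compounds shown here, compound 2 therefore stands at the higher of the two numbers, with compound 1 as its only neighbour, the two lying within the scatter of each other. Compound 3 `COc1cc(/C=C2\CCC/C(=C\c3ccc(O)c(O)c3)C2=O)cc(OC)c1OC` has not yet been measured in this assay. It differs from compound 2 by 3,4-dihydroxyphenyl in place of 3,4-difluorophenyl on a double-bonded chain carbon bound to a double-bonded ring carbon. For the measured compounds named here, the single measured step concerns a change from one fluorinated phenyl to another and does not bear on an exchange of fluorine for hydroxyl; no measured pair speaks to that change. With so little to lean on, the expected step of a 1.4-fold lower number from compound 2 to compound 3 (0.16 log units; within the scatter) is taken as none beyond the scatter, with a wide range of uncertainty. The estimate for compound 3 in this assay is therefore 1600 nM, expected to fall between 400 nM and 6500 nM.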

Compound 3, half-maximal inhibitory concentration: 2700 nM
For compound 3 the middle estimate is 1.7-fold (0.23 log units) below the measured one; the measured number falls inside the stated range.
By their numbers in this assay, from the lowest: compounds 1, 2 and 3 (each within the scatter of the next).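

In this assay, 3,4-dihydroxyphenyl in place of 3,4-difluorophenyl on a double-bonded chain carbon bound to a double-bonded ring carbon gives a 1.2-fold higher number from compound 2 to compound 3 (0.07 log units; within the scatter), and the same group in place of 2-fluorophenyl gives a 1.4-fold higher number from compound 1 to compound 3 (0.15 log units; within the scatter). Among these compounds, the earlier pair compared only two fluorinated phenyl groups, whereas these steps show that a phenyl group bearing hydrogen-bond donors, which 3,4-difluorophenyl lacks, also leaves the number within the scatter of both fluorinated compounds. No measurement is available that would explain why the three compounds lie so close together.

Going by these compounds, all three compounds carry a substituted phenyl group at this place, so it remains open whether a different kind of group there, such as an amine, a carboxylic acid or a longer chain, would move the number beyond the scatter. On these data alone, it also remains open whether a phenyl group with a single hydroxyl, or an unsubstituted phenyl, would fall within the same narrow band, and whether the same closeness would appear in other cell lines.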